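The compounds below may be only part of what the source reports. "The series", "measured", "known", "first", "only" and "open" are said of these compounds alone.

Measured compounds in a functional assay on MDA-MB-231 cells (Homo sapiens) for antiproliferative activity, with a stated time of 4 days; a higher number here means a weaker inhibitor, a lower number a stronger inhibitor:

Compound 1, `COc1ccc(-c2[nH]c3ccc(C(C)C)cc3c2C=O)cc1`: 29 nM
Compound 2, `COc1ccc(-c2[nH]c3ccc(C(C)(C)C)cc3c2C=O)cc1`: 280 nM
Compound 3, `CCCCc1ccc2[nH]c(-c3ccc(C(F)(F)F)cc3)c(C=O)c2c1`: 33 nM

Compound 1 and compound 2 share a core and differ by one change, (methyl in place of hydrogen on a saturated chain carbon bound to an aromatic carbon and two saturated chain carbons). This change gave a 9.7-fold higher number from compound 1 to compound 2 (0.98 log units; beyond the scatter). Compound 3 carries a different core; the difference between the core of compound 1 and the core of compound 3 is not broken down here. The value of compound 3 sits within the scatter of compound 1, so no order between these two is claimed.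

Compound 4, `CCCCCc1ccc2[nH]c(-c3ccc(C(F)(F)F)cc3)c(C=O)c2c1`, is not yet measured. It differs from compound 3 by methyl in place of hydrogen on a saturated chain carbon, four bonds along the chain from an aromatic carbon. For the measured compounds named here, this is the same kind of change as the one from compound 1 to compound 2, but the place is not the same: in the earlier pair the added methyl enters on a saturated chain carbon bound to an aromatic carbon and two saturated chain carbons, whereas here it enters on a saturated chain carbon, four bonds along the chain from an aromatic carbon. The earlier step therefore serves only as a loose guide, and the change of core between compound 1 and compound 3 adds further uncertainty.

Given that compound 3 gives 33 nM, and that the only comparable step on record is the one from compound 1 to compound 2, a smaller loss is expected for compound 4, on the order of a 1.7-fold higher number from compound 3 to compound 4 (0.22 log units; within the scatter) in this assay. Compound 4 is thus estimated at 55 nM, with a plausible range from 20 nM to 160 nM.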

Compound 4, half-maximal inhibitory concentration: 42 nM
The estimate for compound 4 lay 1.3-fold (0.12 log units) above the measured number; the measured number falls inside the stated range.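

In this assay, methyl in place of hydrogen on a saturated chain carbon, four bonds along the chain from an aromatic carbon, gives a 1.3-fold higher number from compound 3 to compound 4 (0.10 log units; within the scatter). Set beside the earlier step, the size of this change did not carry over from one core to the other in this series: the same change on two cores in this assay, a 9.7-fold higher number (0.98 log units; beyond the scatter) from compound 1 to compound 2 and a 1.3-fold higher number (0.10 log units; within the scatter) from compound 3 to compound 4, 7.6-fold (0.88 log units) apart, beyond the scatter of two such steps What this does not show is whether the core or the place of the methyl accounts for the gap, as the two pairs differ in both, the earlier methyl entering on a saturated chain carbon bound to an aromatic carbon and two saturated chain carbons; with one pair on each core, no general rule for this change follows.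

The compounds shown leave open how the series responds to a chain longer than that of compound 4, or to a chain ending in an amine or a carboxylic acid. Also open, on these data alone, is how the same chain extension behaves on the core of compound 1, a comparison that would hold the place of the change fixed and vary only the core.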